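A Change at the Ring Nitrogen of Compound 1

The source may report more compounds than this note shows. Statements on the series, on what has been measured and on what is new or still open speak of the compounds shown alone.

Compound 1: `O=C(O)c1cccc(S(=O)(=O)N2CCC(NS(=O)(=O)c3cc(S(=O)(=O)c4ccccc4)ccc3C(F)(F)F)CC2)c1`, 190 nM
Compound 2: `O=S(=O)(NC1CCN(S(=O)(=O)c2cccc(-c3nnn[nH]3)c2)CC1)c1cc(S(=O)(=O)c2ccccc2)ccc1C(F)(F)F`, 1200 nM
Compound 3: `CC(C)(C)OC(=O)N1CCC(C(=O)N2CCC(NS(=O)(=O)c3cc(S(=O)(=O)c4ccccc4)ccc3C(F)(F)F)CC2)CC1`, 420 nM

In an assay on U2OS cells for inhibition of secreted frizzled-related protein 1 (Homo sapiens), read by a luciferase reporter, with a stated time of 18 h (on this read-out higher numbers stand for an effect only at larger amounts of compound and lower numbers for an effect already at smaller amounts), compound 1 gives the lowest of the three numbers; compound 3 lies nearest to it and compound 2 furthest. Among the compounds with values here, the one measured step that changes the same part of the molecule is a 6.3-fold higher number from compound 1 to compound 2 (0.80 log units; beyond the scatter). Compound 3 carries a different group on the same ring nitrogen and gives 420 nM, against 190 nM for compound 1.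

Compound 4, `O=C(CC1CCNCC1)N1CCC(NS(=O)(=O)c2cc(S(=O)(=O)c3ccccc3)ccc2C(F)(F)F)CC1`, has not been measured. It differs from compound 1 as follows: ((piperidin-4-yl)methyl)carbonyl in place of (3-carboxyphenyl)sulfonyl on an amine nitrogen in a ring. Both changes known so far at this position led to higher numbers, and compound 4 is closer in kind to compound 3 than to compound 2. Compound 4 is therefore expected to give a step of a 3.2-fold higher number from compound 1 to compound 4 (0.50 log units; beyond the scatter) in this assay, a higher number beyond the scatter. The estimate for compound 4 in this assay is 600 nM, with a range from 200 nM to 2000 nM.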

Compound 4, half-maximal effective concentration: 210 nM
Beside the measured number, compound 4's estimate is 2.9-fold (0.46 log units) above it, and the stated range covers the measured number.
By their numbers in this assay, from the lowest: compounds 1, 4 and 3 (each within the scatter of the next, the first and the last beyond it); then compound 2.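

In this assay, the replacement gives a 1.1-fold higher number from compound 1 to compound 4 (0.04 log units; within the scatter). Both earlier changes at this position came with numbers beyond the scatter of compound 1, whereas this one, on an amine nitrogen in a ring, does not, so the (3-carboxyphenyl)sulfonyl group with its aromatic ring is not needed for a number in this range. Nothing measured here explains why two such different groups read alike.

On these data alone, it remains open whether the nitrogen of the piperidin-4-yl ring in compound 4 matters, a question that a cyclohexyl ring in its place could answer. As far as these compounds go, it is also open how far the chain can vary, for example whether a carbonyl attached directly to the piperidine ring, or a longer alkyl chain before it, would read the same way.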